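Swapping the Amide Substituent: Compound 3 to Compound 4

This account rests on a few compounds, and the source may have more. Where it says the series, first, only, none or still open, it means among the compounds named here.

Values in an ADME assay on MT4 cells (Homo sapiens) for cytotoxicity, read by MTT assay, with a stated time of 5 days (a higher number here means that more compound is tolerated, a lower number that less compound is tolerated), are as follows
- compound 1 `Cc1cc(C)cc(S(=O)(=O)c2c(C(=O)N[C@H]3CCN(S(C)(=O)=O)C3)[nH]c3ccc(Cl)cc23)c1` gives 29900 nM as a measured number
- compound 2 `Cc1cc(C)cc(S(=O)(=O)c2c(C(=O)NC3CN(Cc4ccccc4F)C3)[nH]c3ccc(Cl)cc23)c1` gives > 238000 nM as a limit of the assay, not a number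
- compound 3 `Cc1cc(C)cc(S(=O)(=O)c2c(C(=O)NC3CN(CC(N)=O)C3)[nH]c3ccc(Cl)cc23)c1` gives 25500 nM as a measured number
- compound 4 `Cc1cc(C)cc(S(=O)(=O)c2c(C(=O)NS(=O)(=O)C3CC3)[nH]c3ccc(Cl)cc23)c1` has no value yet

Compound 3 shares the low end of these numbers with compound 1, and one step (an at least 9.3-fold lower number from compound 2 to compound 3 (0.97 log units; beyond the scatter)) sets it apart from the remaining measured compound. The change to compound 4 is cyclopropylsulfonyl in place of 1-(carbamoylmethyl)azetidin-3-yl on an amide-type nitrogen. Two measured swaps at that nitrogen bear on it, one within the scatter (a 1.2-fold lower number from compound 1 to compound 3 (0.07 log units; within the scatter)) and one beyond it (an at least 7.9-fold higher number from compound 1 to compound 2 (0.90 log units; beyond the scatter)). Neither brought in cyclopropylsulfonyl, so little beyond the scatter is expected, leaning upward (a 1.6-fold higher number from compound 3 to compound 4 (0.20 log units; within the scatter)). Compound 4 is estimated at 40000 nM with a range running from 12000 nM up to 200000 nM as the expected bounds.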

Compound 4, half-maximal cytotoxic concentration: 147000 nM
Beside the measured number, compound 4's estimate is 3.7-fold (0.57 log units) below it, within the range that was stated.
By their numbers in this assay, from the lowest: compounds 3 and 1 (each within the scatter of the next); then compound 4. At a limit, above all of these: compound 2.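

In this assay, cyclopropylsulfonyl on the amide-type nitrogen gives a 5.8-fold higher number from compound 3 to compound 4 (0.76 log units; beyond the scatter) and a 4.9-fold higher number from compound 1 to compound 4 (0.69 log units; beyond the scatter), so this position does not need a nitrogen-bearing ring for more compound to be tolerated. Compound 2 stands at a limit of the assay, not a number, so an at least 1.6-fold lower number from compound 2 to compound 4 (0.20 log units; that floor lies within the scatter) gives only a floor: the limit of > 238000 nM in this assay, at which 1 of the 4 values shown sits. Whether the three-membered ring or the sulfonyl link accounts for the rise stays open, as the compounds shown do not separate them. A plain methylsulfonyl or a phenylsulfonyl on the same nitrogen would bear on that question.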